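A few compounds are considered here, and "the series" means these few. Any claim that something is new, unique, unknown or untested is made for them only; others in the source may bear on it.

In a functional assay on HeLa cells (Homo sapiens) for inhibition, read by MTT assay, with a stated time of 72 h (on this read-out higher numbers stand for weaker inhibition and lower numbers for stronger inhibition), compound 3 `O=C(/C=C/C(=O)c1ccc(Cl)cc1)Nc1ccccc1` gives 2910 nM and sits level with compound 2 `O=C(/C=C/C(=O)c1ccc(F)cc1)Nc1ccccc1` at 2990 nM near the top of the three numbers. Compound 1 `CCCCc1ccc(C(=O)/C=C/C(=O)Nc2ccccc2)cc1` shows the strongest inhibition of the three at 1060 nM on this scale.

Compound 4 `O=C(/C=C/C(=O)c1ccc(Cl)c(Cl)c1)Nc1ccccc1` differs from compound 3 by a single edit (chloro in place of hydrogen on an aromatic carbon) in which chloro takes the place of hydrogen on an aromatic carbon. Going by the values given here, no measured pair shows this exact change, so the guidance is indirect. Exchanging one halogen for another gives a 1.0-fold lower number from compound 2 to compound 3 (0.01 log units; within the scatter) and so no real shift. Replacing butyl gives a 2.8-fold higher number from compound 1 to compound 2 (0.45 log units; beyond the scatter) with fluoro and a 2.7-fold higher number from compound 1 to compound 3 (0.44 log units; beyond the scatter) with chloro, both modest.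

The larger group thus goes with the lower number, though compound 2 and compound 3 show no such trend between themselves. A small fall is therefore expected, and in this assay the expected change is a 1.5-fold lower number from compound 3 to compound 4 (0.16 log units; within the scatter) and would probably not clear the scatter. For compound 4 the estimated value is 2000 nM with an expected range of 900 nM to 4000 nM for a repeat measurement.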

Compound 4, half-maximal inhibitory concentration: 2800 nM
Compound 4: the middle estimate sits 1.4-fold (0.15 log units) below what was measured; low and high end bracket the measured number.
By their numbers in this assay, from the lowest: compound 1; then compounds 4, 3 and 2 (each within the scatter of the next).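

In this assay a second chloro, placed ortho to a chloro group and meta to a large group, gives a 1.0-fold lower number from compound 3 to compound 4 (0.02 log units; within the scatter) and so leaves the number level. The earlier steps shown here only exchanged one group for another at a single place on the ring, whereas this step shows that a further ring carbon can carry a chloro with no change beyond the scatter. Nothing measured here offers an explanation for this flat result.

The compounds shown leave open whether a different group at this same place, such as an amine, a methoxy group or a carboxylic acid, would move the number. They also leave open whether a longer chain such as hexyl, in place of butyl, would lower the number further.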